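The source may hold more compounds than are shown below. What is called first, only, known or untested is meant among the compounds shown, and "the series" means these compounds.

Measured in a functional assay on A549 cells (Homo sapiens) for cytotoxicity, read by sulforhodamine B assay, with a stated time of 48 h; on this read-out lower numbers stand for stronger inhibition and higher numbers for weaker inhibition:
Compound 1 `COc1ccc(/C=C/C(=O)c2ccc(NC(C)=O)c(-c3ccc(F)cc3)c2)cc1OC`: 7380 nM
Compound 2 `COc1ccc(/C=C/C(=O)c2cccc(-c3cccc(F)c3)c2)cc1OC`: 1940 nM

Of these two numbers, compound 1 holds the higher, at 7380 nM, and so shows the weaker inhibition. Compound 2 stands lower, and the gap between them lies beyond the usual scatter. Compound 3 `COc1ccc(/C=C/C(=O)c2ccc(N)c(-c3ccc(F)cc3)c2)cc1OC` is the next to be tested in this assay. It comes from compound 1 by putting hydrogen in place of acetyl on a nitrogen on an aromatic ring, which turns acetamido to amino: hydrogen in place of acetyl on a nitrogen on an aromatic ring. For the measured compounds named here, no measured pair isolates this change, so the expectation is only a modest step toward a lower number, one that may not clear the scatter. The expected size is a 1.8-fold lower number from compound 1 to compound 3 (0.27 log units; within the scatter). For compound 3 the estimated value is 4000 nM, with an expected range from 1500 nM to 10000 nM.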

Compound 3, half-maximal inhibitory concentration: 8630 nM
The estimate for compound 3 lay 2.2-fold (0.33 log units) below the measured number; low and high end bracket the measured number.
By their numbers in this assay, from the lowest: compound 2; then compounds 1 and 3 (each within the scatter of the next).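

In this assay, for the compounds shown here, the pair of compound 1 and compound 3 is the first to isolate hydrogen in place of acetyl on a nitrogen on an aromatic ring, and it gives a 1.2-fold higher number from compound 1 to compound 3 (0.07 log units; within the scatter). At this position, therefore, going from acetamido to amino produces no difference that this read-out can separate from the usual scatter. No measurement at hand bears on why the two compounds read alike.

On these data alone, whether other groups on this nitrogen, such as a methyl group, a longer acyl chain or a methanesulfonyl group, would also leave the number within the scatter remains open. Compound 2 differs from compound 1 and compound 3 in more than one place, so it cannot show whether the same change would read alike on another core.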